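Quinoline ketone series: removing the ring methyl

A few compounds are considered here, and "the series" means these few. Any claim that something is new, unique, unknown or untested is made for them only; others in the source may bear on it.

Three compounds have numbers in an assay for inhibition of 17-beta-hydroxysteroid dehydrogenase type 2 (Homo sapiens), read by HPLC, with a stated time of 10 min, tested at 1 uM; a higher number here means more inhibition at the concentration tested (going by the name of the read-out), a lower number less inhibition. Compound 1 `C=C(c1ccc(F)c(O)c1)c1cccc(-c2cccc(O)c2F)n1` gives 100%, and compound 3 `CN(c1ccc(F)c(O)c1)c1cccc(-c2cccc(O)c2F)n1` gives 100% in this assay; these two cannot be told apart. Compound 2 `Cc1ccc2nc(C(=O)c3ccc(F)c(O)c3)ccc2c1` gives 78% in this assay, the lowest of the three numbers, and its gap to compound 1 and to compound 3 is each beyond the usual scatter. Within the data shown here, compound 2 differs from the other two in its core and in carrying a carbonyl link, but no single-change pair connects it to them, so no step is drawn.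

Compound 4 `O=C(c1ccc(F)c(O)c1)c1ccc2ccccc2n1` has not yet been measured in this assay. It differs from compound 2 in one place: hydrogen in place of methyl on an aromatic carbon. The change is small in count, a single carbon atom leaving and nothing but a hydrogen entering, at the place described above on the fused ring. Among the measured compounds shown here, no measured pair within this set shows what such a change does in this assay, so the size of the step is open. The expectation is a step from compound 2 to compound 4 of about a number 6 percentage points lower from compound 2 to compound 4 (within the scatter), which is within the scatter and carries no reliable direction. Compound 4 is estimated to give 72% in this assay, with a range from 48% to 92%.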

Compound 4, a percentage reported as inhibition, at one concentration (the size of the read-out at that concentration, not a potency): 76%
The estimate for compound 4 lay 4 percentage points below the measured number, and the stated range covers the measured number.
By their numbers in this assay, from the lowest: compounds 4 and 2 (each within the scatter of the next); then compounds 1 and 3 (each within the scatter of the next).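

Among these compounds, the first single-change pair reads, in this assay, a number 2 percentage points lower from compound 2 to compound 4 (within the scatter) for hydrogen in place of methyl on an aromatic carbon, at the place on the fused system that is meta to a fused ring and para to a fused ring. Among the compounds shown here, at this place and with this change, the methyl therefore makes no readable difference to the percentage at the one concentration tested, and the step gives no direction, something that the earlier compounds, with no connecting pair among them, could not show. Nothing measured beyond the inhibition read-out bears on this step, and the pair offers no explanation for it.

Only methyl and hydrogen are compared at this place, so the compounds shown leave open whether a methoxy group, a chlorine atom, an amine, a carboxylic acid or a longer alkyl chain there would move the number beyond the scatter. Also open, on these data alone, is whether the same exchange would read the same way at another carbon of the fused system, or on a compound with a different link in place of the carbonyl.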